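Hydroxymethyl in place of benzyl on an acrylamide

A few compounds are considered here, and "the series" means these few. Any claim that something is new, unique, unknown or untested is made for them only; others in the source may bear on it.

The account follows two measured compounds and one still to be tested in an ADME assay for pharmacokinetics, read by LC-MS, in phosphate buffer, with a stated time of 120 min, at pH 7.4, tested at 1 uM, in the presence of a further agent that is not named here; a lower number here means that the compound disappears faster, a higher number that the compound lasts longer. Compound 1 has the structure `C=C(Cc1ccccc1)C(=O)Nc1ccccc1`. In this assay compound 1 gives > 8.53 h, which is a limit of the assay rather than a number, so its exact position is not known, as noted in the limit of > 8.53 h in this assay, at which 1 of the 2 values shown sits. Compound 2, with the structure `O=C(/C=C/C(F)(F)F)Nc1ccccc1`, gives in this assay 0.267 h. Among the compounds with values here, no step between two measured compounds that differ in one place is available here. Compound 3 has the structure `C=C(CO)C(=O)Nc1ccccc1`; its change from compound 1 is hydroxy in place of phenyl on a saturated chain carbon bound to a double-bonded chain carbon. A step from compound 1 to compound 3 in this assay is expected to be small or within the scatter, as an at least 1.4-fold lower number from compound 1 to compound 3 (0.15 log units; that floor lies within the scatter). Compound 3 is therefore expected to give about 6 h in this assay, with a range from 1.5 h to 20 h.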

Compound 3, half-life: > 8.53 h
Compound 3: a limit, no number (the forecaster's own chance of this, stated with the estimate: 45%); at least 1.4-fold (0.15 log units) between middle value and limit.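

Within the data shown here, compound 1 and compound 3 both stand at a limit of the assay rather than at a number, so no step from one to the other can be read: the limit of > 8.53 h in this assay, at which 2 of the 3 values shown sit.

The compounds shown leave open how long either compound lasts, and whether hydroxy in place of phenyl changes the half-life at all.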